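The source may hold more compounds than are shown below. What is called first, only, known or untested is meant among the compounds shown, and "the series" means these compounds.

Measured so far:
- compound 1 (`COc1cccc(/C=C\c2ccc3ccccc3c2)c1`) with 1920 nM
- compound 2 (`COc1cc(/C=C\c2ccc3ccccc3c2)ccc1F`) with 450 nM

In a functional assay on P388 cells (Mus musculus) for inhibition (a higher number here means a weaker inhibitor, a lower number a stronger inhibitor), compound 1 stands highest of the two at 1920 nM and is the weaker inhibitor of the pair. The unmeasured compound 3 (`FC(F)(F)Oc1cccc(/C=C\c2ccc3ccccc3c2)c1`) departs from it by one change (trifluoromethyl in place of methyl on an oxygen on an aromatic ring), trifluoromethyl in place of methyl on an oxygen on an aromatic ring, or methoxy to trifluoromethoxy.

Within the data shown here, only one measured step bears on this, and only loosely (a 4.3-fold lower number from compound 1 to compound 2 (0.63 log units; beyond the scatter)). That modest step puts fluoro in place of hydrogen on an aromatic carbon, not on the oxygen. Among the measured compounds shown here, no measured compound changes the methyl itself, so the direction remains uncertain. A step smaller than that one is expected in this assay, leaning toward a lower number, and it may well stay within the scatter. The estimated change is small (a 1.5-fold lower number from compound 1 to compound 3 (0.17 log units; within the scatter)) and its range is wide. For compound 3 the expected value is 1300 nM with an estimated range (450 nM to 3800 nM).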

Compound 3, half-maximal inhibitory concentration: 3500 nM
Beside the measured number, compound 3's estimate is 2.7-fold (0.43 log units) below it; the range from low to high includes it.
By their numbers in this assay, from the lowest: compound 2; then compounds 1 and 3 (each within the scatter of the next).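

In this assay, the methyl on the oxygen was replaced by trifluoromethyl, and the result was a small step (a 1.8-fold higher number from compound 1 to compound 3 (0.26 log units; within the scatter)) that does not separate compound 3 from compound 1. Among these compounds, this is the first reading at the methoxy group itself, and it shows that this exchange on the oxygen, unlike the fluoro on an aromatic carbon (a 4.3-fold lower number from compound 1 to compound 2 (0.63 log units; beyond the scatter)), leaves the number within the scatter rather than beyond it. Nothing measured here speaks to why the two changes read differently, so no explanation can be offered for the result.

The compounds shown leave open whether the oxygen substituent matters at all in this assay, since a single exchange cannot say how a free hydroxyl, an ethoxy group or a longer alkoxy chain would read in the same place. They also leave open whether the trifluoromethoxy group would keep the same small step if it were paired with the aromatic fluoro of compound 2, or whether the two changes would act together on the shared core.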